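The compounds below may be only part of what the source reports. "The series", "measured", "known", "first", "only" and "open" are said of these compounds alone.

Working notes on the series, read in a functional assay for inhibition, with Rattus norvegicus as the target; a higher number here means a weaker inhibitor, a lower number a stronger inhibitor:

- compound 1 `CC(/N=c1\c(O)c(O)\c1=N/c1cccnc1)C(C)(C)C` gives 1950 nM
- compound 2 `C[C@@H](/N=c1\c(O)c(O)\c1=N/c1cccnc1)C(C)(C)C` gives 1900 nM
- compound 3 `CC(/N=c1\c(O)c(O)\c1=N/c1cccnc1O)C(C)(C)C` gives > 30000 nM (a limit)

Compound 2 stands level with compound 1 at the low end of the numbers, with a 1.0-fold lower number from compound 1 to compound 2 (0.01 log units; within the scatter). Compound 4 `CCC/N=c1\c(O)c(O)\c1=N/c1cccnc1` carries propyl in place of 1,2,2-trimethylpropyl on a double-bonded nitrogen. Among the measured compounds shown here, no measured step touches this group. The step of a 1.0-fold lower number from compound 1 to compound 2 (0.01 log units; within the scatter) reflects only (the fact that one of compounds 1 and 2 is drawn with a defined configuration and the other without, at the place where they differ), and an at least 15-fold higher number from compound 1 to compound 3 (1.18 log units; beyond the scatter) is a hydroxy in place of hydrogen on an aromatic carbon. For the measured compounds named here, compound 3 shows only that a single change can move this series sharply upward, so a moderate rise in this assay is expected, with wide uncertainty, as a 3.2-fold higher number from compound 2 to compound 4 (0.50 log units; beyond the scatter). The estimate for compound 4 is 6000 nM, within 1800 nM to 25000 nM.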

Compound 4, half-maximal inhibitory concentration: > 30000 nM
Compound 4 ended at the assay's limit (the forecaster's own chance of this, stated with the estimate: 20%); middle value at least 5.0-fold (0.69 log units) from the limit.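

The group on the double-bonded nitrogen, untouched by any earlier step, now proves to matter: with propyl in place of 1,2,2-trimethylpropyl, the steps read an at least 15-fold higher number from compound 2 to compound 4 (1.19 log units; beyond the scatter) and an at least 15-fold higher number from compound 1 to compound 4 (1.18 log units; beyond the scatter). Compound 4 gives > 30000 nM, which is a limit of the assay. Alongside the hydroxy change in compound 3, this is a second single change that takes the series to the limit.

Still open, from the compounds shown here alone, is how a tert-butyl or cyclohexyl group on the double-bonded nitrogen would read, and whether a chain ending in an amine or a carboxylic acid would hold the number.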